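Lipophilicity in a sulfonyl salicylanilide series: extending the chain

The compounds below may be only part of what the source reports. "The series", "measured", "known", "first", "only" and "open" are said of these compounds alone.

Measured so far:
- compound 1, `CCCCS(=O)(=O)c1ccc(O)c(C(=O)Nc2ccc(Br)cc2)c1`: 2.48
- compound 2, `CCCCCCCCCCCCS(=O)(=O)c1ccc(O)c(C(=O)Nc2ccc(Br)cc2)c1`: 6.49
- compound 3, `CCCCS(=O)(=O)c1ccc(O)c(C(=O)Nc2ccc(C(F)(F)F)cc2)c1`: 3.1

In a physicochemical assay for lipophilicity (on this read-out higher numbers stand for higher lipophilicity and lower numbers for lower lipophilicity), compound 3 stands second highest of the three numbers; its nearest neighbour is compound 1, and compound 2 lies far above it. The step of a number 0.62 log units higher from compound 1 to compound 3 (beyond the scatter) was modest, while a number 4.01 log units higher from compound 1 to compound 2 (beyond the scatter) was large.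

Compound 4, `CCCCCCCCCCS(=O)(=O)c1ccc(O)c(C(=O)Nc2ccc(C(F)(F)F)cc2)c1`, has not yet been measured. It differs from compound 3 as follows: hexyl in place of hydrogen on a saturated chain carbon, four bonds along the chain from a sulfonyl sulfur. Among the measured compounds shown here, the only measured step of this kind is a number 4.01 log units higher from compound 1 to compound 2 (beyond the scatter), where the added chain was octyl rather than hexyl; no other pair in this set bears on it. A large upward step in this assay is therefore expected, somewhat smaller than the measured one because a number 4.01 log units higher from compound 1 to compound 2 (beyond the scatter) came with octyl, a longer chain than the hexyl entering here. The step of a number 3.00 log units higher from compound 3 to compound 4 (beyond the scatter) is the estimated size. Compound 4 is expected to give 6.1, with a range of 5.5 to 6.7.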

Compound 4, distribution coefficient: 6.34
Compound 4: the middle estimate sits 0.24 log units below what was measured; low and high end bracket the measured number.
By their numbers in this assay, from the lowest: compound 1; then compound 3; then compounds 4 and 2 (each within the scatter of the next).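

Hexyl in place of hydrogen on this saturated chain carbon gives a number 3.24 log units higher from compound 3 to compound 4 (beyond the scatter) in this assay and this step is large. Large rises at this carbon now appear with two different aromatic substituents, with octyl entering alongside bromo and hexyl entering alongside trifluoromethyl, and no compound shown goes against this. Nothing on hand explains the size of either step.

On these data alone, with only these two chain extensions, it remains open whether the number keeps rising for a longer chain such as hexadecyl or how it behaves for a shorter one such as ethyl at this position. Also open, as far as these compounds go, is what a polar end group on the chain, such as an amine or a carboxylic acid, would do to the number in this assay on this core.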